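Adding 4-methylpiperazin-1-yl to compound 2

The compounds below may be only part of what the source reports. "The series", "measured", "known", "first", "only" and "open" are said of these compounds alone.

Compound 1 `Cc1ccccc1Nc1nc(NC2CCCCC2)ncc1Cl`: > 100000 nM (a limit)
Compound 2 `Cc1ccccc1Nc1nc(Nc2ccccn2)ncc1Cl`: 11200 nM

In a functional assay on MDA-MB-231 cells (Homo sapiens) for inhibition, read by CCK-8 assay, with a stated time of 48 h (on this read-out lower numbers stand for stronger inhibition of growth and higher numbers for weaker inhibition of growth), compound 1 gives > 100000 nM, which is a limit and not a number. For the measured compounds named here, compound 2 gives 11200 nM, the only true number so far. Compound 3 `Cc1ccccc1Nc1nc(Nc2ccc(N3CCN(C)CC3)cn2)ncc1Cl` keeps the pyridin-2-yl group of compound 2 and changes that ring: 4-methylpiperazin-1-yl in place of hydrogen on an aromatic carbon. Going by the values given here, no measured step covers this place. The nearest evidence is an at least 8.9-fold lower number from compound 1 to compound 2 (0.95 log units; beyond the scatter), which lies beyond the scatter and concerns the group on the same nitrogen, so it bears on this change only indirectly. On that slender basis, a modest move toward a lower number in this assay is expected. The expected change is a 3.7-fold lower number from compound 2 to compound 3 (0.57 log units; beyond the scatter). Compound 3 is estimated at 3000 nM, with an expected range from 600 nM to 15000 nM.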

Compound 3, concentration for 50% growth inhibition: 7470 nM
Estimate against measurement, compound 3: 2.5-fold (0.40 log units) below, within the range that was stated.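

In this assay, this is the only step shown that alters the pyridin-2-yl ring itself rather than the group on the nitrogen, and it shows that the position two atoms from the ring nitrogen can carry 4-methylpiperazin-1-yl. The step is a 1.5-fold lower number from compound 2 to compound 3 (0.18 log units; within the scatter), so a group of 7 heavy atoms, with its non-aromatic ring, enters in place of hydrogen without a change that can be told from the scatter. The one line of support concerns compound 1, whose value is a limit, and it says nothing about this position: the limit of > 100000 nM in this assay, at which 1 of the 3 values shown sits.

From the compounds shown here alone, whether a different group at this position, such as morpholine, a primary amine or a carboxylic acid, would shift the number beyond the scatter remains open. Also open, going by these compounds, is whether a longer chain ending in an amine would behave as 4-methylpiperazin-1-yl does here.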